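This account rests on a few compounds, and the source may have more. Where it says the series, first, only, none or still open, it means among the compounds named here.

The measured compounds and their values in a functional assay on HepG2 cells (Homo sapiens) for cytotoxicity, read by MTT assay, with a stated time of 24 h (on this read-out higher numbers stand for weaker inhibition and lower numbers for stronger inhibition), are:
compound 1, `COc1cc(/C=C2\CN(S(=O)(=O)c3ccc(F)cc3)C/C(=C\c3cccc([N+](=O)[O-])c3)C2=O)cc(OC)c1OC`, 3250 nM;
compound 2, `COc1cc(/C=C2\CN(S(=O)(=O)c3ccc(F)cc3)C/C(=C\c3ccc(C#N)cc3)C2=O)cc(OC)c1OC`, 4950 nM;
compound 3, `CC(=O)Nc1ccc(S(=O)(=O)N2C/C(=C\c3cccc([N+](=O)[O-])c3)C(=O)/C(=C/c3ccccc3F)C2)cc1`, 8800 nM.

Compound 1 and compound 2 share one core and differ in a single place: 4-cyanophenyl in place of 3-nitrophenyl on a double-bonded chain carbon bound to a double-bonded ring carbon. That change made a step of a 1.5-fold higher number from compound 1 to compound 2 (0.18 log units; within the scatter), so the two numbers cannot be told apart with confidence. Compound 3 carries a different core; the difference between the two cores is not broken down here. The gap between compound 3 and compound 1 lies beyond the scatter, while the gap between compound 3 and compound 2 lies within it.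

Compound 4, `CC(=O)Nc1ccc(S(=O)(=O)N2C/C(=C\c3ccc(C#N)cc3)C(=O)/C(=C/c3ccccc3F)C2)cc1`, has not yet been measured. It stands to compound 3 as compound 2 stands to compound 1: 4-cyanophenyl in place of 3-nitrophenyl on a double-bonded chain carbon bound to a double-bonded ring carbon. The place of the change is described in the same words in both pairs, so this is the same kind of change, made on a different core. Because the earlier step was a 1.5-fold higher number from compound 1 to compound 2 (0.18 log units; within the scatter), the step now expected is of similar small size, a 1.5-fold higher number from compound 3 to compound 4 (0.17 log units; within the scatter), and is expected to remain within the scatter. This rests on one earlier example only, so it is a guide rather than a rule. Compound 4 is therefore estimated at 13000 nM, with a likely range from 5500 nM to 30000 nM.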

Compound 4, half-maximal inhibitory concentration: 4960 nM
Beside the measured number, compound 4's estimate is 2.6-fold (0.42 log units) above it; measured number below the stated range.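

In this assay, putting 4-cyanophenyl in place of 3-nitrophenyl gave a 1.8-fold lower number from compound 3 to compound 4 (0.25 log units; within the scatter), so on its own this pair of numbers cannot be told apart with confidence. Set beside the earlier example, however, the change did not give the same step on both cores, and a step measured on one core therefore did not simply transfer to the other: the same change on two cores in this assay, a 1.5-fold higher number (0.18 log units; within the scatter) from compound 1 to compound 2 and a 1.8-fold lower number (0.25 log units; within the scatter) from compound 3 to compound 4, 2.7-fold (0.43 log units) apart, beyond the scatter of two such steps. Among these compounds, this shows that, in this small series, the core can matter to what the change does, but it does not show why the two steps differ, and with only two pairs it gives no rule for any further core.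

The two cores differ in more than one place, so the compounds shown leave open which part of the core goes with the difference between the steps, and pairs that change one part of the core at a time would be needed to separate them. They also leave open how other groups would behave in the same place, on a double-bonded chain carbon bound to a double-bonded ring carbon, such as an amine or a carboxylic acid in place of the nitrile or the nitro group.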